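The source may report more compounds than this note shows. Statements on the series, on what has been measured and on what is new or still open speak of the compounds shown alone.

Compounds measured in a functional assay on MDA-MB-231 cells (Homo sapiens) for inhibition, read by sulforhodamine B assay, tested at 10 uM; a higher number here means more inhibition at the concentration tested (going by the name of the read-out), a lower number less inhibition:
- compound 1 `CN(C)c1ccc(C2CC(c3ccc(-n4cncn4)cc3)=NN2)cc1`: 7%
- compound 2 `CN1CCN(c2ccc(C3=NN(C(=O)CCCl)C(c4ccc(N(C)C)cc4)C3)cc2)CC1`: 2.4%
- compound 3 `CC(=O)N1N=C(c2ccc(-n3cncn3)cc2)CC1c1ccc(N(C)C)cc1`: 7.4%

Compound 3 holds the highest of the three numbers, but its gap to compound 1 and to compound 2 is within the scatter, so the three numbers stand level with one another, all low. Among the compounds with values here, the one measured step, a number 0.4 percentage points higher from compound 1 to compound 3 (within the scatter), left the number unchanged in effect.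

Compound 4 `CN(C)c1ccc(C2CC(c3ccc(-n4cncn4)cc3)=NN2C(=O)CCCl)cc1` carries chloromethyl in place of hydrogen on a saturated chain carbon bound to a carbonyl carbon. Within the data shown here, no measured step bears directly on this change; compound 2, which has the same (2-chloroethyl)carbonyl group on a different core, shows 2.4%, again low. The expectation is therefore that compound 4 stays in the same low band, with a number 1.4 percentage points lower from compound 3 to compound 4 (within the scatter) lying within the scatter. Compound 4 is estimated at 6%, between 0% and 14%.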

Compound 4, a percentage reported as inhibition, at one concentration (the size of the read-out at that concentration, not a potency): 3.7%
Compound 4: middle estimate off by 2.3 percentage points, on the high side, and the stated range covers the measured number.
By their numbers in this assay, from the lowest: compounds 2, 4, 1 and 3 (each within the scatter of the next).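

In this assay the change from acetyl to (2-chloroethyl)carbonyl on the amine nitrogen in a ring reads a number 3.7 percentage points lower from compound 3 to compound 4 (within the scatter) and the same group in place of hydrogen reads a number 3.3 percentage points lower from compound 1 to compound 4 (within the scatter) so neither acyl group at this position separates from the others. With (2-chloroethyl)carbonyl held fixed, the aromatic change from 4-methylpiperazin-1-yl to 1H-1,2,4-triazol-1-yl reads a number 1.3 percentage points higher from compound 2 to compound 4 (within the scatter) and also stays level. No evidence bears on these results.

Still open, on these data alone, is whether an amine or a carboxylic acid in place of the chlorine on this chain would carry the number beyond the scatter.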